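A few compounds are considered here, and "the series" means these few. Any claim that something is new, unique, unknown or untested is made for them only; others in the source may bear on it.

In a functional assay on A549 cells (Homo sapiens) for antiproliferative activity, read by MTT assay, with a stated time of 48 h (on this read-out higher numbers stand for weaker inhibition and lower numbers for stronger inhibition), compound 1 (`c1ccc(-c2nn(-c3ccccc3)cc2-c2nc3ccccc3[nH]2)cc1`) gives 2710 nM and its fluoro analogue, compound 2 (`Fc1ccc2[nH]c(-c3cn(-c4ccccc4)nc3-c3ccccc3)nc2c1`), gives 1720 nM. These two values lie within the scatter of each other, as a 1.6-fold lower number from compound 1 to compound 2 (0.20 log units; within the scatter) shows. Compound 3 (`O=C(OCc1ccccc1)c1ccc2[nH]c(-c3cn(-c4ccccc4)nc3-c3ccccc3)nc2c1`) gives 19300 nM and stands well apart. Benzyloxycarbonyl in place of hydrogen brings a 7.1-fold higher number from compound 1 to compound 3 (0.85 log units; beyond the scatter), and the same group in place of fluoro brings an 11-fold higher number from compound 2 to compound 3 (1.05 log units; beyond the scatter). Compound 2 therefore sits with compound 1 at the low end of the numbers shown.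

Compound 4 (`COc1ccc(-c2nn(-c3ccccc3)cc2-c2nc3cc(F)ccc3[nH]2)cc1`) keeps the fluoro group of compound 2 but turns a phenyl into 4-methoxyphenyl: methoxy in place of hydrogen on an aromatic carbon. This places methoxy in place of hydrogen on an aromatic carbon, para to a large group. Within the data shown here, none of the measured steps alters that ring, so they offer only a loose guide. One small substitution, in a 1.6-fold lower number from compound 1 to compound 2 (0.20 log units; within the scatter), stayed within the scatter, while the two benzyloxycarbonyl steps show that the numbers in this series can move widely. Among the measured compounds shown here, with no direct precedent, no shift in either direction beyond the scatter is expected, though the uncertainty is wide. The expected change is a 1.0-fold lower number from compound 2 to compound 4 (0.01 log units; within the scatter). For compound 4 the estimated value is 1700 nM, with an expected range from 500 nM to 6000 nM.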

Compound 4, half-maximal inhibitory concentration: 1980 nM
For compound 4 the middle estimate is 1.2-fold (0.07 log units) below the measured one; the measured number falls inside the stated range.
By their numbers in this assay, from the lowest: compounds 2, 4 and 1 (each within the scatter of the next); then compound 3.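

In this assay, among these compounds, the change from phenyl to 4-methoxyphenyl gives a 1.2-fold higher number from compound 2 to compound 4 (0.06 log units; within the scatter), the first measured step at this ring, which none of the earlier steps touched. It shows that methoxy can stand in place of hydrogen on this aromatic carbon, para to a large group, with compound 4 remaining within the scatter of compound 2, whereas the benzyloxycarbonyl step at a different place, from compound 2 to compound 3, went beyond the scatter. Nothing available here accounts for the absence of a clear shift at this position.

On these data alone, a single substituent cannot show how much this position accepts, so it remains open whether an amine, a carboxylic acid or a longer chain in the same place would also stay within the scatter or would move the number clearly in either direction. It is also open whether methoxy would behave the same way without the fluoro group of compound 2, since the compounds shown test this change only with that group in place.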